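Dihalophenyl versus methoxyphenyl at the carbonyl

The compounds below may be only part of what the source reports. "The series", "measured", "known", "first", "only" and "open" are said of these compounds alone.

Measured compounds:
compound 1 `COc1cc(-c2cc(/C=C/C(=O)c3ccc(Cl)c(Cl)c3)[nH]n2)cc(OC)c1OC`: 40%
compound 2 `COc1ccc(C(=O)/C=C/c2cc(-c3cc(OC)c(OC)c(OC)c3)n[nH]2)cc1OC`: -89%
compound 3 `COc1ccc(C(=O)/C=C/c2cc(-c3cc(OC)c(OC)c(OC)c3)n[nH]2)cc1`: -8%

In a functional assay on OVCAR-8 cells (Homo sapiens) for cytotoxicity, read by sulforhodamine B assay, with a stated time of 48 h, tested at 10 uM (on this read-out higher numbers stand for a weaker effect at the one concentration tested and lower numbers for a stronger effect), compound 3 stands second highest of the three numbers, with compound 1 higher by a number 48 percentage points lower from compound 1 to compound 3 (beyond the scatter) reversed and compound 2 lower by a number 81 percentage points higher from compound 2 to compound 3 (beyond the scatter) reversed. The unmeasured compound 4 `COc1cc(-c2cc(/C=C/C(=O)c3ccc(F)c(F)c3)[nH]n2)cc(OC)c1OC` differs from compound 3 by 3,4-difluorophenyl in place of 4-methoxyphenyl on a carbonyl carbon. Within the data shown here, the one step that bears on this change is the move from a dihalophenyl to a methoxyphenyl on the same carbonyl carbon, a number 48 percentage points lower from compound 1 to compound 3 (beyond the scatter), a large drop; compound 4 reverses that direction with a different halogen pair. A rise beyond the scatter is therefore expected for compound 4, of about a number 33 percentage points higher from compound 3 to compound 4 (beyond the scatter), though the two halogens are not the same. Compound 4 is estimated at 25%, with a range from -20% to 55%.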

Compound 4, a percentage reported as activity, at one concentration (the size of the read-out at that concentration, not a potency): 4%
Estimate against measurement, compound 4: 21 percentage points above; low and high end bracket the measured number.
By their numbers in this assay, from the lowest: compound 2; then compound 3; then compound 4; then compound 1.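

In this assay the halogen pair itself counts, not the mere presence of halogens on the phenyl at the carbonyl carbon: 3,4-difluorophenyl gives a number 36 percentage points lower from compound 1 to compound 4 (beyond the scatter) against 3,4-dichlorophenyl. The difluoro group lies close to 4-methoxyphenyl, with a number 12 percentage points higher from compound 3 to compound 4 (beyond the scatter) as a modest step, while a number 93 percentage points higher from compound 2 to compound 4 (beyond the scatter) leaves 3,4-dimethoxyphenyl well apart from it. No measurement here explains these differences.

On these data alone, a single halogen, as in 4-fluorophenyl, remains open at this carbonyl carbon. So does a phenyl bearing an amine or a carboxylic acid.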